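Trimming the Pentamethylphenyl Ring: What Compound 4 Might Tolerate

The source may report more compounds than this note shows. Statements on the series, on what has been measured and on what is new or still open speak of the compounds shown alone.

Of the compounds shown here, three sharing one core have been measured in an ADME assay on Huh7.5.1 cells (Homo sapiens) for cytotoxicity, read by ATP content, with a stated time of 48 h; a lower number here means that less compound is tolerated, a higher number that more compound is tolerated. Compound 1, `Cc1oc(-c2c(C)c(C)c(C)c(C)c2C)nc1CN1CCC(C(=O)NCCCN2C[C@H](C)C[C@H](C)C2)CC1`, gives 8180 nM. Compound 2, `Cc1ccccc1-c1nc(CN2CCC(C(=O)NCCCN3CC4CCCC(C4)C3)CC2)c(C)o1`, gives 10900 nM, and compound 3, `Cc1ccccc1-c1nc(CN2CCC(C(=O)NCCN3C[C@H](C)C[C@H](C)C3)CC2)c(C)o1`, gives 24400 nM. Compound 1 thus has the lowest of the three numbers; its gap to compound 2 lies within the scatter, while compound 3 stands clearly higher. Going by the values given here, the only single-point step among the measured compounds, a 2.2-fold higher number from compound 2 to compound 3 (0.35 log units; beyond the scatter), concerns the chain and the saturated ring at its end, not the aromatic ring at the other end of the core.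

Compound 4, `Cc1cccc(-c2nc(CN3CCC(C(=O)NCCCN4C[C@H](C)C[C@H](C)C4)CC3)c(C)o2)c1`, differs from compound 1 by 3-methylphenyl in place of 2,3,4,5,6-pentamethylphenyl on an aromatic carbon. Among the compounds with values here, no measured step touches this aromatic ring, so nothing in the numbers points to a change in either direction, and the closest guide is that compounds 2 and 3, which carry a smaller aromatic ring, sit at or above compound 1. A step of about a 1.5-fold higher number from compound 1 to compound 4 (0.17 log units; within the scatter) is therefore expected, within or near the scatter. Compound 4 is estimated at 12000 nM, with a range from 5000 nM to 30000 nM.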

Compound 4, half-maximal cytotoxic concentration: 16500 nM
Compound 4: middle estimate off by 1.4-fold (0.14 log units), on the low side, within the range that was stated.
By their numbers in this assay, from the lowest: compounds 1, 2, 4 and 3 (each within the scatter of the next, the first and the last beyond it).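

In this assay, going by these compounds alone, this is the first look at the aromatic group on the carbon of the five-membered ring that lies next to the ring nitrogen and the ring oxygen. Putting 3-methylphenyl in place of 2,3,4,5,6-pentamethylphenyl gives a 2.0-fold higher number from compound 1 to compound 4 (0.30 log units; within the scatter) and stays within the usual scatter. The two compounds therefore cannot be told apart here, even though the groups differ in size and in their methyl pattern, and no independent evidence bears on this result.

The compounds shown leave open how an unsubstituted phenyl ring or a pyridine ring would read at this position. They also leave open whether a chlorine or a methoxy group on the phenyl ring would give a step beyond the scatter.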